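A few compounds are considered here, and "the series" means these few. Any claim that something is new, unique, unknown or untested is made for them only; others in the source may bear on it.

Two compounds have been run in a functional assay on the whole organism for antagonist activity, with Rattus norvegicus as the target; a higher number here means that more compound is needed for the effect, a lower number that less compound is needed. Compound 1, `CN(C)c1ncnc2c1ncn2Cc1cccc(N)c1`, gives 23 mg/kg in this assay. Compound 2, `Clc1nc(NC2CC2)c2ncn(CC3CC3)c2n1`, gives 2.5 mg/kg in this assay, the lower of the two numbers; the gap from compound 1 to compound 2 is beyond the usual scatter of repeated measurements, so compound 2 is the one of the two that needs the smaller dose. The two structures differ in many places at once, so nothing can be read from their pair about any single change.

Compound 3, `CNc1nc(NC2CC2)c2ncn(CC3CC3)c2n1`, has not been measured. It differs from compound 2 in one place: methylamino in place of chloro on an aromatic carbon. Among the compounds with values here, no measured pair shows the effect of that change on the shared core, so its direction has to be taken as open. The step is expected to be small, within the scatter or close to it, with a slight lean toward a higher dose; in that case the expected step is a 1.4-fold higher number from compound 2 to compound 3 (0.15 log units; within the scatter). In this assay compound 3 is expected to give about 3.5 mg/kg, with a range from 1.2 mg/kg to 12 mg/kg.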

Compound 3, dose for half-maximal effect: 3 mg/kg
Compound 3: middle estimate off by 1.2-fold (0.07 log units), on the high side; measured number inside the range.
By their numbers in this assay, from the lowest: compounds 2 and 3 (each within the scatter of the next); then compound 1.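

On this aromatic carbon, between two ring nitrogen atoms, the series gains its first comparison that differs in one place only: in this assay, methylamino in place of chloro gives a 1.2-fold higher number from compound 2 to compound 3 (0.08 log units; within the scatter), so the two compounds cannot be told apart. The exchange brings in one hydrogen-bond donor and one hydrogen-bond acceptor where chloro carried neither, and with the cyclopropylamino group and the rest of the shared core unchanged, the dose read-out shows no difference beyond the scatter. No measurement is available here that would explain this result.

The compounds shown leave open whether the same holds for other groups on this carbon, such as an unsubstituted amine, an ethylamino chain or a methoxy group, any of which would test the position further on the shared core. Within the data shown here, they also leave open what the cyclopropylamino group itself contributes, as compound 1 differs from the other two in many places at once and yields no single-place step.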